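The compounds below may be only part of what the source reports. "The series", "measured", "known", "first", "only" and "open" are said of these compounds alone.

Of the compounds shown here, two built on one shared core have been tested in an ADME assay on microsomes from liver (Mus musculus) for metabolic stability, read by LC-MS, using NADPH, tested at 1 uM; a higher number here means that the compound lasts longer, a lower number that the compound disappears faster. Compound 1 `Cc1cnc(NC(=O)CCCOc2cncc(Cl)c2)s1` gives 0.1 h in this assay. Compound 2 `Cc1cnc(NC(=O)CCCOc2cccc(C#N)c2)s1` gives 0.0667 h, the lower of the two numbers, though its gap to compound 1 lies within the scatter, so the two cannot be told apart. Compound 3 `Cc1cnc(NC(=O)CCCOc2ccccc2)s1` has not yet been measured. It differs from compound 2 in one place: hydrogen in place of cyano on an aromatic carbon. Within the data shown here, no measured pair shows this same change, so there is no direct guide to what it does in this assay. Among the measured compounds shown here, with only two measured compounds, and those indistinguishable, the step from compound 2 to compound 3 is expected to stay within the scatter, with no clear direction, a 1.0-fold higher number from compound 2 to compound 3 (0.02 log units; within the scatter). Compound 3 is therefore estimated at 0.07 h, with a range from 0.03 h to 0.16 h.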

Compound 3, half-life in the Mus musculus assay: 0.0333 h
For compound 3 the middle estimate is 2.1-fold (0.32 log units) above the measured one; the range from low to high includes it.
By their numbers in the Mus musculus assay, from the lowest: compounds 3, 2 and 1 (each within the scatter of the next, the first and the last beyond it).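

Among these compounds, in the Mus musculus assay, the pair gives the first direct reading of hydrogen in place of cyano on this aromatic carbon, meta to a large group: a 2.0-fold lower number from compound 2 to compound 3 (0.30 log units; within the scatter), so the two compounds cannot be told apart and the cyano group shows no clear effect here. In a physicochemical assay for solubility, read by nephelometry, in phosphate buffer, at pH 6.5 (a higher number here means a more soluble compound, a lower number a less soluble compound), compound 2 gives < 1100 nM, which is a limit of the assay and not a number. In the physicochemical assay compound 3 gives < 1100 nM, again a limit, so the step between the two cannot be read: the limit of < 1100 nM in the physicochemical assay, at which 2 of the 2 values shown sit.

On these data alone, it remains open whether an amine or a carboxylic acid at this same place would give a half-life clearly apart from these in the Mus musculus assay. Also open, as far as these compounds go, is whether either group would give a readable number in the physicochemical assay.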